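A few compounds are considered here, and "the series" means these few. Any claim that something is new, unique, unknown or untested is made for them only; others in the source may bear on it.

Compound 1 `Cc1c(S(=O)(=O)NC(C)(C)C)ccc(-c2sc(C(=O)N[C@H]3C[C@H](C(=O)O)C3)nc2CC2CCCCC2)c1OC(F)F` and compound 2 `CC(C)(O)CNC(=O)c1nc(CC2CCCCC2)c(-c2cnc(S(=O)(=O)NC(C)(C)C)c3ccccc23)s1` are the two compounds measured here. In a physicochemical assay for solubility, read by HPLC, in phosphate buffer, measured as thermodynamic solubility, with a stated time of 5 days, at pH 2, tested at 10 mM (a higher number here means a more soluble compound, a lower number a less soluble compound), compound 1 gives < 1000 nM, which is a limit of the assay rather than a number. Compound 2 gives < 4000 nM in this assay, again only a limit. Within the data shown here, compound 2 thus stands at a limit, and no step between the two measured compounds is counted. Compound 3 `CC(C)(C)NS(=O)(=O)c1ncc(-c2sc(C(=O)N[C@H]3C[C@H](C(=O)O)C3)nc2CC2CCCCC2)c2ccccc12` differs from compound 2 by 3-carboxycyclobutyl in place of 2-hydroxy-2-methylpropyl on an amide-type nitrogen. The entering group already stands in compound 1. The step that the limit leaves unreadable from compound 2 to compound 3 is expected to be none beyond the scatter. Compound 3 is estimated at 800 nM, ranging from 200 nM to 3000 nM.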

Compound 3, solubility: < 1000 nM
Compound 3: a limit, no number (the forecaster's own chance of this, stated with the estimate: 70%); the middle value is on the limit's open side.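

Among these compounds, compound 2 and compound 3 both stand at limits in this assay, so no step between them can be read. The compounds shown leave open how soluble each actually is, and whether 3-carboxycyclobutyl in place of 2-hydroxy-2-methylpropyl changes the read-out at all.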